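A few compounds are considered here, and "the series" means these few. Any claim that something is new, unique, unknown or untested is made for them only; others in the source may bear on it.

Measured so far in a functional assay on MDA-MB-231 cells (Homo sapiens) for inhibition, read by CCK-8 assay, with a stated time of 48 h; on this read-out lower numbers stand for stronger inhibition of growth and higher numbers for weaker inhibition of growth
- compound 1 `COc1ccc(CNc2nc(Nc3ccc(N4CCN(C)CC4)cn3)ncc2Cl)cc1` gives 14900 nM
- compound 2 `CN1CCN(c2ccc(Nc3ncc(Cl)c(Nc4ccc(C(C)(C)C)cc4)n3)nc2)CC1` gives 16200 nM

Compound 2 at 16200 nM lies within the scatter of compound 1 at 14900 nM, so the two cannot be ranked in this assay. Compound 3 `COc1cccc(Nc2nc(Nc3ccc(N4CCN(C)CC4)cn3)ncc2Cl)c1` carries 3-methoxyphenyl in place of 4-(tert-butyl)phenyl on a nitrogen on an aromatic ring. Within the data shown here, one measured step bears on this place, the replacement of 4-methoxybenzyl by 4-(tert-butyl)phenyl, which gave a 1.1-fold higher number from compound 1 to compound 2 (0.04 log units; within the scatter). Among the measured compounds shown here, that single step is thin evidence, and no 3-methoxyphenyl compound has been measured. No change beyond the scatter is therefore expected, in either direction. The estimated step is a 1.2-fold lower number from compound 2 to compound 3 (0.10 log units; within the scatter). For compound 3 the expected value is 13000 nM, with an estimated range of 4500 nM to 32000 nM.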

Compound 3, concentration for 50% growth inhibition: 8510 nM
For compound 3 the middle estimate is 1.5-fold (0.18 log units) above the measured one; low and high end bracket the measured number.
By their numbers in this assay, from the lowest: compounds 3, 1 and 2 (each within the scatter of the next).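

Three different groups have now been compared on a nitrogen on an aromatic ring, and none is separated from another in this assay. Replacing 4-(tert-butyl)phenyl with 3-methoxyphenyl gives a 1.9-fold lower number from compound 2 to compound 3 (0.28 log units; within the scatter), and replacing 4-methoxybenzyl with 3-methoxyphenyl gives a 1.8-fold lower number from compound 1 to compound 3 (0.24 log units; within the scatter), so neither change moves the read-out beyond the scatter. No available evidence bears on these steps.

On these data alone, whether a group of another kind at this place, such as a phenyl ring carrying an amine or a carboxylic acid, or a longer alkyl chain in place of the ring, would give a step beyond the scatter remains open. The three compounds also leave open how changes elsewhere on the shared core would read in this assay.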